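A Methyl Step Where Only Limits Are Known

This account rests on a few compounds, and the source may have more. Where it says the series, first, only, none or still open, it means among the compounds named here.

In an ADME assay on MT4 cells (Homo sapiens) for cytotoxicity, read by MTT assay (a higher number here means that more compound is tolerated, a lower number that less compound is tolerated), compound 2 `O=C(CSc1nc(Cc2c(F)cccc2Cl)cc(=O)[nH]1)c1ccccc1` gives > 13000 nM, which is a limit and not a number. Compound 3 `COc1ccc(C(=O)CSc2nc(Cc3c(F)cccc3Cl)cc(=O)[nH]2)cc1` gives > 12000 nM, also a limit. Methoxy in place of hydrogen on an aromatic carbon therefore yields a step that the two limits leave unreadable from compound 2 to compound 3.

Compound 4 `Cc1c(Cc2c(F)cccc2Cl)nc(SCC(=O)c2ccccc2)[nH]c1=O` differs from compound 2 by methyl in place of hydrogen on an aromatic carbon, ortho to a 2-chloro-6-fluorobenzyl group. Among the measured compounds shown here, no measured step gives the size of this change. The nearest guide is compound 1 `Cc1c(Cc2c(Cl)cccc2Cl)nc(SCC(=O)c2ccccc2)[nH]c1=O`, which carries a methyl on the same aromatic carbon, although its benzyl group also differs, and it gives > 60000 nM, again a limit. With that limit in view, no loss of tolerance beyond the scatter is expected in this assay. The expected change is a step that the limit leaves unreadable from compound 2 to compound 4. For compound 4 the estimated value is 25000 nM, with an expected range of 10000 nM to 70000 nM.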

Compound 4, half-maximal cytotoxic concentration: > 12000 nM
Compound 4 was reported as a limit; the forecaster's own chance of this, stated with the estimate: 80%; the middle value lies beyond the limit too.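

Among the compounds shown here, compound 4, like compound 1 and compound 2, is reported only as a limit, so neither the step from compound 2 to compound 4 nor the one from compound 1 to compound 4 can be read. The compounds shown leave open whether either change alters tolerance at all.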